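The source may hold more compounds than are shown below. What is called first, only, known or untested is meant among the compounds shown, and "the series" means these compounds.

Compound 1 `COc1ccc(Cn2cnc3c(-c4ccco4)nccc32)cc1` was tested in an ADME assay on Vero cells (Chlorocebus sabaeus) for cytotoxicity; on this read-out lower numbers stand for stronger inhibition and higher numbers for weaker inhibition. In this assay compound 1 gives > 128000 nM, which is a limit of the assay and not a number. Compound 2 `COc1ccc(Cn2cnc3c(-c4ccco4)nc(Cl)cc32)cc1` differs from compound 1 by chloro in place of hydrogen on an aromatic carbon. In this assay compound 2 gives > 128000 nM, again a limit. The step that the two limits leave unreadable from compound 1 to compound 2 cannot be read because of the limit of > 128000 nM in this assay, at which 2 of the 3 values shown sit. Compound 3 `COc1ccc(Cn2ccc3c(-c4ccco4)nccc32)cc1` rests on a different core; the difference between the two cores is not broken down here. In this assay, for the measured compounds named here, compound 3 gives 12000 nM, the only plain number among the three. Compound 4 `COc1ccc(Cn2ccc3c(-c4ccco4)nc(Cl)cc32)cc1` differs from compound 3 by chloro in place of hydrogen on an aromatic carbon, the same change as that from compound 1 to compound 2. With the earlier step unreadable, only a small step is expected, a 1.3-fold lower number from compound 3 to compound 4 (0.12 log units; within the scatter). Compound 4 is estimated at 9000 nM, with 3000 nM to 30000 nM as its likely range.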

Compound 4, half-maximal inhibitory concentration: 58000 nM
Estimate against measurement, compound 4: 6.4-fold (0.81 log units) below; measured number above the stated range.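

In this assay, chloro in place of hydrogen on an aromatic carbon gives a 4.8-fold higher number from compound 3 to compound 4 (0.68 log units; beyond the scatter), so on the core of compound 3 this change means weaker inhibition. The same change from compound 1 to compound 2 cannot be read because neither value is a plain number: the limit of > 128000 nM in this assay, at which 2 of the 4 values shown sit. For the compounds shown here, the result therefore does not show whether the change carries over from one core to the other; it describes only the single pair on the core of compound 3.

As far as these compounds go, it remains open whether a different group on the same aromatic carbon, such as an amine or a nitrile, would shift the number in the same way. From the compounds shown here alone, whether any such group would bring the core of compound 1 to a readable value also remains open.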